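A few compounds are considered here, and "the series" means these few. Any claim that something is new, unique, unknown or untested is made for them only; others in the source may bear on it.

Of the compounds shown here, two that share a common core have been tested in a functional assay on SK-OV-3 cells (Homo sapiens) for cytotoxicity, read by MTT assay, with a stated time of 48 h; on this read-out lower numbers stand for stronger inhibition and higher numbers for weaker inhibition. Compound 1 `O=c1[nH]c2ccccc2cc1-c1nc2cc(Br)ccc2[nH]1` carries a bromo group and gives 11400 nM. Compound 2 `COc1ccc2[nH]c(=O)c(-c3nc4cc([N+](=O)[O-])ccc4[nH]3)cc2c1` carries a methoxy group and a nitro group. In this assay compound 2 gives only a limit, > 100000 nM, so no number is available for it. It stands at the edge of what the numbers shown here cover: the limit of > 100000 nM in this assay, at which 1 of the 2 values shown sits. Among the compounds with values here, compound 1 and compound 2 differ in two places, so their values show only that one gives a number and the other a limit.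

Compound 3 `COc1ccc2[nH]c(=O)c(-c3nc4cc(Br)ccc4[nH]3)cc2c1` has not yet been measured. It differs from compound 2 by bromo in place of nitro on an aromatic carbon. Compound 3 thus combines the methoxy group of compound 2 with the bromo group of compound 1, and compound 1, with that same bromo group, gives 11400 nM. The step is therefore expected to be a gain beyond the usual scatter: an at least 5.0-fold lower number from compound 2 to compound 3 (0.69 log units; beyond the scatter). In this assay compound 3 is expected to give 20000 nM, within a range of 6000 nM to 80000 nM.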

Compound 3, half-maximal inhibitory concentration: > 100000 nM
Compound 3: no number, only a limit; the forecaster's own chance of this, stated with the estimate: 25%; middle value at least 5.0-fold (0.69 log units) away from the limit.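

In this assay, within the data shown here, methoxy in place of hydrogen on an aromatic carbon, with the bromo group kept, gives an at least 8.7-fold higher number from compound 1 to compound 3 (0.94 log units; beyond the scatter), and this is the first step that can be read. Bromo in place of nitro at this position does not lift compound 3 clear of the limit that compound 2 already sits at, so with the methoxy group present, the bromo group that accompanies a number in compound 1 yields only a limit here, and the step between these two limits cannot be read. Both methoxy-bearing compounds now end at the same edge of the range: the limit of > 100000 nM in this assay, at which 2 of the 3 values shown sit.

The compounds shown leave open how far past the limit compound 2 and compound 3 lie, and so whether nitro and bromo differ at all in this setting. Also open, from the compounds shown here alone, is whether the change is specific to methoxy, or whether another group in its place, such as a hydroxyl or an amine, would give a number as compound 1 does.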